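Lengthening the hydroxamic acid chain from compound 2

A few compounds are considered here, and "the series" means these few. Any claim that something is new, unique, unknown or untested is made for them only; others in the source may bear on it.

Measured in a functional assay on HeLa cells (Homo sapiens) for inhibition, read by MTT assay, with a stated time of 72 h; on this read-out higher numbers stand for weaker inhibition and lower numbers for stronger inhibition (both values are limits):
- compound 1 `Nc1nc2cc(-c3nn(CCCC(=O)NO)c4ncnc(N)c34)ccc2o1` gives > 150000 nM
- compound 2 `Nc1nc2cc(-c3nn(CCC(=O)NO)c4ncnc(N)c34)ccc2o1` gives > 150000 nM

Compound 2 stands only at > 150000 nM, which is a limit and not a number. Compound 3 `Nc1nc2cc(-c3nn(CCCCC(=O)NO)c4ncnc(N)c34)ccc2o1` differs from it by 2-(hydroxycarbamoyl)ethyl in place of hydroxycarbamoyl on a saturated chain carbon, two bonds along the chain from an aromatic nitrogen. Going by the values given here, the one measured step on chain length, a step that the two limits leave unreadable from compound 1 to compound 2, has no readable size, and both compounds rest at the limit of > 150000 nM in this assay, at which 2 of the 2 values shown sit. It therefore supports no direction for the new step, and none beyond the scatter can be firmly expected. The expected step is a number no higher from compound 2 to compound 3 (the limit leaves the size open). For compound 3 the estimated value is 150000 nM, with an expected range of 40000 nM to 300000 nM.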

Compound 3, half-maximal inhibitory concentration: 32200 nM
Compound 3: middle estimate off by 4.7-fold (0.67 log units), on the high side, and the stated range ends above it.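

In this assay, 2-(hydroxycarbamoyl)ethyl in place of hydroxycarbamoyl gives the series its first readable number, with an at least 4.6-fold lower number from compound 2 to compound 3 (0.66 log units; beyond the scatter) and an at least 4.6-fold lower number from compound 1 to compound 3 (0.66 log units; beyond the scatter). So chain length at this position can move the value beyond the scatter, and both steps give only a minimum size. The step between the two shorter chains still cannot be read, and their values remain limits: the limit of > 150000 nM in this assay, at which 2 of the 3 values shown sit.

On these data alone, whether a longer chain would lower the number further or raise it again stays open. Also open, as far as these compounds go, is whether a carboxylic acid or an amine in place of the hydroxycarbamoyl end would keep any of this inhibition.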